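From Cyclopentyl to 2-Bromophenyl on a Shared Core

A few compounds are considered here, and "the series" means these few. Any claim that something is new, unique, unknown or untested is made for them only; others in the source may bear on it.

Compound 1 `COc1ccc(-c2cnc(NC(=O)c3ccno3)n2C)cc1` and compound 2 `COc1ccc(-c2cnc(NC(=O)C3CCCC3)n2C)cc1` share one core and differ only in the group on a carbonyl carbon. In a toxicity assay on THP-1 cells (Homo sapiens) for inhibition (on this read-out higher numbers stand for lower toxicity in this test and lower numbers for higher toxicity in this test), compound 1 gives > 100000 nM as a limit of the assay. In this assay compound 2 gives > 100000 nM as a limit of the assay. Compound 2 therefore stands at the limit of > 100000 nM in this assay, at which 2 of the 2 values shown sit, with no exact number to place it. Compound 3 `COc1ccc(-c2cnc(NC(=O)c3ccccc3Br)n2C)cc1` carries 2-bromophenyl in place of cyclopentyl on a carbonyl carbon and has yet to be measured. Among the measured compounds shown here, the one measured step that the two limits leave unreadable from compound 1 to compound 2 has no size to carry over. Nothing in it points to a shift beyond the scatter, so the step expected in this assay is a number no higher from compound 2 to compound 3 (the limit leaves the size open) with no firm direction. For compound 3 the estimate is 100000 nM with an expected range from 40000 nM to 200000 nM and another limit is quite likely.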

Compound 3, half-maximal cytotoxic concentration: > 100000 nM
Compound 3: a limit, no number; the forecaster's own chance of this, stated with the estimate: 75%; the middle value lies on the limit itself.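

In this assay compound 3 gives > 100000 nM, a limit of the assay. Among the compounds shown here, no step can therefore be read from compound 1 or compound 2 to compound 3. The compounds shown leave open what exact number, if any, each of the three would reach.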